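A few compounds are considered here, and "the series" means these few. Any claim that something is new, unique, unknown or untested is made for them only; others in the source may bear on it.

Of the compounds shown here, two sharing one core have so far been read in an ADME assay on cells (Hepatocyte, Rattus norvegicus) for pharmacokinetics; on this read-out lower numbers stand for slow clearance and higher numbers for fast clearance: compound 1 (`Cc1cc(C)c2cc(C(=O)NC3CN(c4cc(Cl)ncc4Cl)C3)ccc2n1`) gives 56.6 mL/min/kg and compound 2 (`Cc1cc(C)c2cc(C(=O)NC3CN(c4ccnc(F)c4F)C3)ccc2n1`) gives 53.8 mL/min/kg. For the measured compounds named here, compound 2 therefore stands level with compound 1, since the only measured step, a 1.1-fold lower number from compound 1 to compound 2 (0.02 log units; within the scatter), does not leave the scatter. Compound 3 (`COc1cc(N2CC(NC(=O)c3ccc4nc(C)cc(C)c4c3)C2)c(Cl)cn1`) keeps the core and alters the same place as that step, with 5-chloro-2-methoxypyridin-4-yl in place of 2,3-difluoropyridin-4-yl on an amine nitrogen in a ring. Going by the values given here, the measured step is the only guide, and it exchanged one substituted pyridinyl group for another on that nitrogen with no shift in this assay beyond the scatter. Among the compounds with values here, no measured compound carries a methoxy group, so that part of the change remains untested and the range must stay wide. On this thin evidence, no real shift is expected, and the step is estimated as a 1.1-fold lower number from compound 2 to compound 3 (0.03 log units; within the scatter). For compound 3 the expected clearance is 50 mL/min/kg, with an estimated range from 28 mL/min/kg to 85 mL/min/kg.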

Compound 3, clearance: 50.2 mL/min/kg
Estimate against measurement, compound 3: 1.0-fold (0.00 log units) below, within the range that was stated.
By their numbers in this assay, from the lowest: compounds 3, 2 and 1 (each within the scatter of the next).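

In this assay, the place on the amine nitrogen in the four-membered ring now also accepts a group bearing methoxy with no shift beyond the scatter: 5-chloro-2-methoxypyridin-4-yl in place of 2,3-difluoropyridin-4-yl gives a 1.1-fold lower number from compound 2 to compound 3 (0.03 log units; within the scatter). The pair that differs only in one substituent isolates the methoxy group itself, and methoxy in place of chloro on an aromatic carbon gives a 1.1-fold lower number from compound 1 to compound 3 (0.05 log units; within the scatter), so the one feature that neither earlier compound carried also stays within the scatter. All three substituted pyridinyl groups at this place therefore read alike, and nothing at hand bears on why this is so.

Going by these compounds, it remains open whether a group of another kind on this nitrogen, such as a plain phenyl ring or a pyridinyl ring bearing a carboxylic acid or an amine, would move the clearance beyond the scatter. It is equally open whether any change to the amide or to the shared core would do so, since every compound shown keeps both unchanged.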